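This account rests on a few compounds, and the source may have more. Where it says the series, first, only, none or still open, it means among the compounds named here.

Measured compounds:
Compound 1 `CCN(CC)Cc1ccc2nc(NC(=O)N/N=C/c3c[nH]c4ccccc34)sc2c1` — 3300 nM
Compound 2 `CN(C)Cc1ccc2nc(NC(=O)N/N=C/c3c[nH]c4ccccc34)sc2c1` — 3300 nM

In a functional assay on A549 cells (Homo sapiens) for cytotoxicity, read by MTT assay, with a stated time of 72 h (on this read-out lower numbers stand for stronger inhibition and higher numbers for weaker inhibition), compound 1 gives 3300 nM, and compound 2 gives 3300 nM; the step of no change at the digits printed from compound 1 to compound 2 (within the scatter) lies within the scatter. Compound 1 therefore stands level with compound 2. Compound 3 `CCN(CC)Cc1ccc2nc(NC(=O)N/N=C/c3cn(Cc4ccc(Cl)c(Cl)c4)c4ccccc34)sc2c1` is not yet measured. It differs from compound 1 by 3,4-dichlorobenzyl in place of hydrogen on an aromatic nitrogen. Among the compounds with values here, no measured step touches this position; the only known step, no change at the digits printed from compound 1 to compound 2 (within the scatter), concerns the saturated chain carbon and was flat. With nothing to anchor the change, no step beyond the scatter is assumed: a 1.1-fold lower number from compound 1 to compound 3 (0.04 log units; within the scatter) is the expected step. The value of compound 3 is estimated at 3000 nM, in the range 700 nM to 13000 nM.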

Compound 3, half-maximal inhibitory concentration: 1470 nM
Beside the measured number, compound 3's estimate is 2.0-fold (0.31 log units) above it; the range from low to high includes it.
By their numbers in this assay, from the lowest: compound 3; then compounds 1 and 2 (each within the scatter of the next).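

In this assay, placing 3,4-dichlorobenzyl on the aromatic nitrogen gives a 2.2-fold lower number from compound 1 to compound 3 (0.35 log units; beyond the scatter), a modest step and the first beyond the scatter among these compounds. This position therefore accepts the substituent with no loss of activity and with a small gain, whereas the earlier pair spoke only to the saturated chain carbon. Nothing available explains this step. The compounds shown leave open how a plain benzyl or a methyl on the same nitrogen would compare. They also leave open whether the same change would give a similar step on compound 2.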